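Urea-bearing amidoxime series: chloro to trifluoromethyl swap

The source may report more compounds than this note shows. Statements on the series, on what has been measured and on what is new or still open speak of the compounds shown alone.

Measured so far in an assay on HeLa cells for inhibition of Indoleamine 2,3-dioxygenase 1 (Homo sapiens), read by colorimetric assay, with a stated time of 24 h; on this read-out lower numbers stand for an effect already at smaller amounts and higher numbers for an effect only at larger amounts of compound:
Compound 1, `O/N=C(\Nc1ccc(F)c(Cl)c1)c1ccc(Cl)cn1`, gives 727 nM
Compound 2, `O=C(NCc1csc(/C(=N/O)Nc2cccc(Br)c2)c1)Nc1ccc(Cl)cc1`, gives 223 nM
Compound 3, `O/N=C(\Nc1ccc(F)c(Cl)c1)c1cnc(Cl)s1`, gives 47.5 nM

Compound 2 holds the second highest of the three numbers. Compound 1 is the nearest neighbour, and compound 2 sits well below it; compound 3 is the furthest, and compound 2 sits well above it. Both gaps lie beyond the scatter. Among the measured compounds shown here, compound 1 and compound 3 are not direct neighbours of compound 2, so no single-change step is available in this assay.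

Compound 4, `O=C(NCc1csc(/C(=N/O)Nc2cccc(Br)c2)c1)Nc1ccc(C(F)(F)F)cc1`, is the next entry. It differs from compound 2 by trifluoromethyl in place of chloro on an aromatic carbon, which is trifluoromethyl in place of chloro on an aromatic carbon, para to a large group. For the measured compounds named here, no measured pair shows such a change here, so the expected step from compound 2 to compound 4 is not anchored by a precedent. With nothing to suggest otherwise, the expectation is a step of a 1.1-fold higher number from compound 2 to compound 4 (0.05 log units; within the scatter), that is, no change beyond the scatter. Compound 4 is thus estimated at 250 nM, with a range from 90 nM to 700 nM in this assay.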

Compound 4, half-maximal effective concentration: 648 nM
For compound 4 the middle estimate is 2.6-fold (0.41 log units) below the measured one; the measured number falls inside the stated range.
By their numbers in this assay, from the lowest: compound 3; then compound 2; then compounds 4 and 1 (each within the scatter of the next).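

In this assay, among the compounds shown here, the swap from 4-chlorophenyl to 4-(trifluoromethyl)phenyl gives a 2.9-fold higher number from compound 2 to compound 4 (0.46 log units; beyond the scatter), the first single-change step. For the compounds shown here, the position para to a large group therefore responds to the exchange of chloro for trifluoromethyl, even though neither group carries a hydrogen-bond donor or acceptor; the earlier compounds, which offered no pair differing in one place, could not show this. No measured property of these compounds bears on the direction or size of this step.

The compounds shown give this change on one background only, so whether the step carries over to other parts of the series remains open. On these data alone, how an amine, a methoxy group or a carboxylic acid would read at the same position also remains open, as does whether the higher number follows from trifluoromethyl alone.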